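From Benzoyl to Cyclopentylmethyl Amide on a Shared Core

A few compounds are considered here, and "the series" means these few. Any claim that something is new, unique, unknown or untested is made for them only; others in the source may bear on it.

The measured compounds:
compound 1, `O=C(Nc1cc(-c2ccccc2)nn1-c1ccccc1)c1ccccc1`: 203 nM
compound 2, `O=C(Nc1cc(-c2ccccc2)nn1-c1cccc(Br)c1)c1ccccc1`: 400 nM
compound 3, `N#Cc1cccc(-n2nc(-c3ccccc3)cc2NC(=O)c2ccccc2)c1`: 117 nM

In a functional assay on cells for positive allosteric modulation of metabotropic glutamate receptor 5 (Rattus norvegicus), read by calcium flux (on this read-out lower numbers stand for an effect already at smaller amounts and higher numbers for an effect only at larger amounts of compound), compound 1 gives 203 nM, the second highest of the three numbers. Compound 3 is nearest, at 117 nM, and compound 2 furthest, at 400 nM. Within the data shown here, the steps of a 1.7-fold lower number from compound 1 to compound 3 (0.24 log units; within the scatter) and a 2.0-fold higher number from compound 1 to compound 2 (0.29 log units; within the scatter) both stay within the scatter, while a 3.4-fold lower number from compound 2 to compound 3 (0.53 log units; beyond the scatter) is the only step beyond it. All three changes sit on the ring attached to the nitrogen of the shared core.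

Compound 4, `O=C(CC1CCCC1)Nc1cc(-c2ccccc2)nn1-c1ccccc1`, is altered elsewhere: cyclopentylmethyl in place of phenyl on a carbonyl carbon Read one bond further out, benzoyl becomes (cyclopentylmethyl)carbonyl. Among the measured compounds shown here, none of the measured steps touches the carbonyl side, so the known numbers give no direct guide to the size of this step. With a non-aromatic ring entering where an aromatic one leaves, a loss is judged more likely than a gain, and the estimate is placed wide. This estimate means an expected step of a 3.0-fold higher number from compound 1 to compound 4 (0.47 log units; beyond the scatter). Compound 4 is therefore expected to give 600 nM, with a range of 150 nM to 2500 nM.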

Compound 4, half-maximal effective concentration: 350 nM
For compound 4 the middle estimate is 1.7-fold (0.23 log units) above the measured one, and the stated range covers the measured number.
By their numbers in this assay, from the lowest: compounds 3, 1, 4 and 2 (each within the scatter of the next, the first and the last beyond it).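

In this assay, among these compounds, the step of a 1.7-fold higher number from compound 1 to compound 4 (0.24 log units; within the scatter) gives the first reading on the carbonyl side of the shared core, as the earlier steps all lay on the ring attached to the nitrogen. At this position, a five-membered non-aromatic ring carried as cyclopentylmethyl can stand in place of phenyl, a six-membered aromatic ring, without a difference beyond the scatter, so an aromatic ring directly on the carbonyl carbon is not needed to keep the number in this range for this pair. No evidence is available that accounts for this result.

The compounds shown leave open how an amine, a carboxylic acid or a longer chain would fare on the carbonyl carbon. They also leave open whether cyclopentylmethyl would give a similar step in the presence of the bromo or cyano groups.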